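Swapping an arylamine for pyrrolidine on a shared core

This account rests on a few compounds, and the source may have more. Where it says the series, first, only, none or still open, it means among the compounds named here.

Compound 2 `COc1ccc(NC2=CC(=O)c3nc4n(c3C2=O)[C@H]2OC[C@@H](O)[C@H]2OC4)cc1` gives 5420 nM in a functional assay on MCF7 cells (Homo sapiens) for inhibition, read by sulforhodamine B assay (a higher number here means a weaker inhibitor, a lower number a stronger inhibitor), the lowest of the two plain numbers shown. Compound 1 `O=C1C=C(Nc2cccc(F)c2)C(=O)c2c1nc1n2[C@H]2OC[C@@H](O)[C@H]2OC1` gives 5500 nM, and the change a 1.0-fold lower number from compound 1 to compound 2 (0.01 log units; within the scatter) stays within the scatter. Compound 3 `CCOc1ccccc1NC1=CC(=O)c2nc3n(c2C1=O)[C@H]1OC[C@@H](O)[C@H]1OC3` reaches only the limit > 4000 nM, so a step that the limit leaves unreadable from compound 1 to compound 3 and a step that the limit leaves unreadable from compound 2 to compound 3 cannot be sized. Compound 4 `O=C1C=C(N2CCCC2)C(=O)c2c1nc1n2[C@H]2OC[C@@H](O)[C@H]2OC1` carries pyrrolidin-1-yl in place of (4-methoxyphenyl)amino on a double-bonded ring carbon. Going by the values given here, none of the measured steps involves this kind of change; all three measured compounds keep an arylamine, and their numbers differ little where readable. Among the compounds with values here, with no step pointing either way, compound 4 is expected to show a 1.3-fold higher number from compound 2 to compound 4 (0.11 log units; within the scatter), a step of no clear direction beyond the scatter. Compound 4 is therefore estimated at 7000 nM, between 2500 nM and 20000 nM.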

Compound 4, half-maximal inhibitory concentration: > 16000 nM
Compound 4: a limit, no number; the forecaster's own chance of this, stated with the estimate: 30%; middle value at least 2.2-fold (0.35 log units) away from the limit.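

Going by these compounds alone, at this position, on a double-bonded ring carbon, the one readable step among the arylamines stayed within the scatter, but pyrrolidin-1-yl in this assay gives a change beyond it: an at least 2.9-fold higher number from compound 2 to compound 4 (0.47 log units; beyond the scatter) and an at least 2.9-fold higher number from compound 1 to compound 4 (0.46 log units; beyond the scatter). Losing the arylamine for this ring therefore goes with a weaker inhibitor than compound 1 or compound 2. Compound 4 stands at a limit, not a number: the limit of > 16000 nM in this assay, at which 1 of the 4 values shown sits.

The steps to compound 3 cannot be read. From the compounds shown here alone, whether a benzylamine or morpholine would stay with the arylamines or fall with pyrrolidine remains open.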